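Azocane in Place of Phenylpiperidine: Compound 4 Expected

A few compounds are considered here, and "the series" means these few. Any claim that something is new, unique, unknown or untested is made for them only; others in the source may bear on it.

Compound 1 `CCCCNc1nc(C(F)(F)F)ccc1CNC(=O)C(C)c1ccc(NS(C)(=O)=O)c(F)c1`: 293 nM in a functional assay on CHO-K1 cells for antagonist activity at transient receptor potential cation channel subfamily V member 1 (Homo sapiens), read by FLIPR; on this read-out higher numbers stand for weaker inhibition and lower numbers for stronger inhibition
Compound 2 `Cc1ccc(Nc2nc(C(F)(F)F)ccc2CNC(=O)C(C)c2ccc(NS(C)(=O)=O)c(F)c2)cc1C`: 1160 nM in this assay
Compound 3 `CC(C(=O)NCc1ccc(C(F)(F)F)nc1N1CCC(c2ccccc2)CC1)c1ccc(NS(C)(=O)=O)c(F)c1`: 25 nM in this assay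

Compound 3 gives the lowest number of the three, with a 12-fold lower number from compound 1 to compound 3 (1.07 log units; beyond the scatter) and a 46-fold lower number from compound 2 to compound 3 (1.67 log units; beyond the scatter); the difference a 4.0-fold higher number from compound 1 to compound 2 (0.60 log units; beyond the scatter) is smaller. Compound 4 `CC(C(=O)NCc1ccc(C(F)(F)F)nc1N1CCCCCCC1)c1ccc(NS(C)(=O)=O)c(F)c1` differs from compound 3 by a group of 8 heavy atoms (7 carbon, 1 nitrogen; one eight-membered non-aromatic ring with 1 hetero atom) in place of a group of 12 heavy atoms (11 carbon, 1 nitrogen; one six-membered non-aromatic ring with 1 hetero atom, one six-membered aromatic ring of carbon only), on an aromatic carbon. Within the data shown here, no measured step removes the phenyl from a cyclic amine at this carbon; the nearest guide is the step from the butylamino compound 1, where the cyclic amine carrying a phenyl brought the large fall a 12-fold lower number from compound 1 to compound 3 (1.07 log units; beyond the scatter). Compound 4 keeps a cyclic amine but loses the phenyl. A moderate rise in this assay is therefore expected, the estimated step being a 4.0-fold higher number from compound 3 to compound 4 (0.60 log units; beyond the scatter). Compound 4 is estimated at 100 nM in this assay, within 30 nM to 400 nM.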

Compound 4, half-maximal inhibitory concentration: 27.8 nM
Compound 4: the middle estimate sits 3.6-fold (0.56 log units) above what was measured; the whole stated range lies above it.
By their numbers in this assay, from the lowest: compounds 3 and 4 (each within the scatter of the next); then compound 1; then compound 2.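

In this assay, a cyclic amine with no phenyl at this aromatic carbon, next to the ring nitrogen, matches the 4-phenylpiperidin-1-yl group (within the scatter: a 1.1-fold higher number from compound 3 to compound 4 (0.05 log units; within the scatter)). The large falls from butylamino (an 11-fold lower number from compound 1 to compound 4 (1.02 log units; beyond the scatter)) and from (3,4-dimethylphenyl)amino (a 42-fold lower number from compound 2 to compound 4 (1.62 log units; beyond the scatter)) therefore do not require that phenyl. Nothing available explains why the two rings give matching numbers.

From the compounds shown here alone, it remains open how a plain piperidin-1-yl or a morpholin-4-yl would compare at this carbon. Also open, going by these compounds, is how a hydroxyl or a carboxylic acid on the eight-membered ring would change the number.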